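The source may hold more compounds than are shown below. What is called first, only, known or untested is meant among the compounds shown, and "the series" means these compounds.

Measured in a functional assay on MDA-MB-468 cells (Homo sapiens) for cytotoxicity, read by MTT assay, with a stated time of 72 h; a higher number here means a weaker inhibitor, a lower number a stronger inhibitor:
- compound 1 `Nc1nc(Nc2ccccc2)sc1C(=O)c1cccnc1`: "not determined" (no result reported)
- compound 2 `Nc1nc(Nc2ccc(S(N)(=O)=O)cc2)sc1C(=O)c1cccnc1`: 2800 nM

The record for this series is thin. In this assay, among the compounds with values here, compound 2 gives 2800 nM, and this is the only number available. Within the data shown here, compound 1 has no reported result, so compound 2 cannot be placed above or below anything, and no measured step exists to show how sensitive the read-out is to a change.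

The next compound to be tested is compound 3 `Nc1nc(Nc2ccc(S(N)(=O)=O)cc2)sc1C(=O)c1ccccc1[N+](=O)[O-]`. It keeps the shared core of compound 2 and differs in one place, with 2-nitrophenyl in place of pyridin-3-yl on a carbonyl carbon.

Among the measured compounds shown here, with no step to scale from, no direction can be favoured, and the expectation in this assay is for no change beyond the scatter, although the uncertainty is wide on both sides. The expected change is a 1.1-fold lower number from compound 2 to compound 3 (0.05 log units; within the scatter). Compound 3 is estimated at 2500 nM, with an expected range from 600 nM to 9000 nM.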

Compound 3, half-maximal inhibitory concentration: 300 nM
Compound 3: middle estimate off by 8.3-fold (0.92 log units), on the high side; measured number outside the range, below it.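

In this assay, the group on the carbonyl carbon proves to matter: putting 2-nitrophenyl in place of pyridin-3-yl gives a 9.3-fold lower number from compound 2 to compound 3 (0.97 log units; beyond the scatter). Within the data shown here, this is the first measured step, and it shows that the read-out responds to a change at this place, here towards a stronger inhibitor when a six-membered aromatic ring of carbon only, carrying a nitro group, replaces one with a hetero atom. Nothing available bears on why the number moves, so the step stands as an observation only.

The single step joins two changes, the loss of the ring nitrogen and the arrival of the nitro group, and the compounds shown leave open which of them accounts for the shift; a plain phenyl on the carbonyl carbon would begin to separate the two. As far as these compounds go, it also remains open whether another group in the place of the nitro group, such as an amine, a nitrile or a carboxylic acid, would keep the lower number seen for compound 3.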